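The source may report more compounds than this note shows. Statements on the series, on what has been measured and on what is new or still open speak of the compounds shown alone.

Measured in a functional assay on A549 cells (Homo sapiens), read by sulforhodamine B assay, with a stated time of 5 days; a higher number here means a weaker inhibitor of growth, a lower number a stronger inhibitor of growth:
Compound 1 `OC[C@H]1O[C@@H](n2cc(F)c3c(-c4ccoc4)ncnc32)[C@H](O)[C@@H]1O`: 60 nM
Compound 2 `OC[C@H]1O[C@@H](n2cc(Cl)c3c(-c4ccccc4)ncnc32)[C@H](O)[C@@H]1O`: 2500 nM
Compound 3 `OC[C@H]1O[C@@H](n2cc(Cl)c3c(-c4cccs4)ncnc32)[C@H](O)[C@@H]1O`: 380 nM

Of these three numbers, that of compound 3 is the middle one. It is lower than that of compound 2 and higher than that of compound 1, and both gaps lie beyond the scatter.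

The next compound, compound 4 `OC[C@H]1O[C@@H](n2cc(Cl)c3c(-c4ccoc4)ncnc32)[C@H](O)[C@@H]1O`, has not yet been measured. It keeps the chlorine of compound 3 and changes one ring, with furan-3-yl in place of thiophen-2-yl on an aromatic carbon.

Within the data shown here, only one measured step involves this same place. Thiophen-2-yl in place of phenyl gave a 6.6-fold lower number from compound 2 to compound 3 (0.82 log units; beyond the scatter), a modest step, so a change of ring here can move the number, though no furan took part in that step. The closest evidence is compound 1 at 60 nM, which already carries furan-3-yl but has fluorine where compound 4 has chlorine. Among the measured compounds shown here, no measured pair isolates that halogen swap, so this evidence is only indirect. A step towards a lower number in this assay is therefore expected, somewhat smaller than the one from phenyl to thiophen-2-yl. The estimate amounts to an expected 3.5-fold lower number from compound 3 to compound 4 (0.54 log units; beyond the scatter). The estimated value for compound 4 is 110 nM, with an expected range of 35 nM to 350 nM.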

Compound 4, concentration for 50% growth inhibition: 1100 nM
Compound 4: middle estimate off by 10-fold (1.00 log units), on the low side, outside the stated range (above it).
By their numbers in this assay, from the lowest: compound 1; then compound 3; then compound 4; then compound 2.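

In this assay, among these compounds, the earlier compounds showed only that a change of ring at this place can move the number; holding the chlorine fixed now lets three rings be compared. Furan-3-yl in place of thiophen-2-yl gives a 2.9-fold higher number from compound 3 to compound 4 (0.46 log units; beyond the scatter) even though both rings have the same heavy-atom count and the same counts of donors and acceptors, while furan-3-yl in place of phenyl gives a 2.3-fold lower number from compound 2 to compound 4 (0.36 log units; beyond the scatter) and so leaves thiophen-2-yl with the lowest number of the three chlorine compounds. With furan-3-yl kept, chloro in place of fluoro gives an 18-fold higher number from compound 1 to compound 4 (1.26 log units; beyond the scatter) as a large step, bigger than any listed ring change here, so the low number of compound 1 cannot be credited to furan-3-yl alone.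

Nothing available here explains why the steps at either place run as they do. As far as these compounds go, it remains open whether thiophen-2-yl would also give a lower number than furan-3-yl on a core carrying fluorine, and how a ring bearing an amine or a carboxylic acid would compare at this place.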